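Hydroxy(phenyl)methyl in Place of Benzoyl: Expected Cytotoxicity

A few compounds are considered here, and "the series" means these few. Any claim that something is new, unique, unknown or untested is made for them only; others in the source may bear on it.

Measured compounds in a functional assay on SQ20B cells (Homo sapiens) for cytotoxicity, read by MTT assay, with a stated time of 72 h; on this read-out lower numbers stand for stronger inhibition and higher numbers for weaker inhibition:
compound 1, `Oc1ccc2oc(Cc3ccccc3)cc2c1CN1CCc2ccccc2C1`, gives 16000 nM;
compound 2, `Oc1ccc2oc(Cc3ccccc3)cc2c1CN1CCC(N2CCCCC2)CC1`, gives 3000 nM;
compound 3, `O=C(c1ccccc1)c1cc2c(CN3CCC(N4CCCCC4)CC3)c(O)ccc2o1`, gives 17000 nM.

Compound 3 stands at the highest of the three numbers; compound 1 lies within the scatter of it, while compound 2 sits well below it. Among the compounds with values here, the single step that speaks to the next change is a 5.7-fold higher number from compound 2 to compound 3 (0.75 log units; beyond the scatter). Compound 4, `Oc1ccc2oc(C(O)c3ccccc3)cc2c1CN1CCC(N2CCCCC2)CC1`, differs from compound 3 by hydroxy(phenyl)methyl in place of benzoyl on an aromatic carbon, so the double bond outside aromatic rings is gone and one hydrogen-bond donor is gained, leaving the group part-way between benzyl and benzoyl. The step is therefore expected to be a 2.1-fold lower number from compound 3 to compound 4 (0.33 log units; beyond the scatter), a partial return toward compound 2 in this assay . Compound 4 is estimated at 8000 nM, with a range from 3000 nM to 20000 nM.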

Compound 4, half-maximal inhibitory concentration: 13000 nM
The estimate for compound 4 lay 1.6-fold (0.21 log units) below the measured number, within the range that was stated.
By their numbers in this assay, from the lowest: compound 2; then compounds 4, 1 and 3 (each within the scatter of the next).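

In this assay hydroxy(phenyl)methyl in place of benzoyl on the aromatic carbon next to the ring oxygen gives a 1.3-fold lower number from compound 3 to compound 4 (0.12 log units; within the scatter), so losing the carbonyl double bond and gaining a hydrogen-bond donor does not separate these two compounds. Hydroxy in place of hydrogen on the saturated chain carbon gives a 4.3-fold higher number from compound 2 to compound 4 (0.64 log units; beyond the scatter), so the lower number of compound 2 is lost with either oxygen-bearing group at this position. Nothing available explains this result. From the compounds shown here alone, whether a methoxy group or an amine on that chain carbon would keep the number of compound 2 remains open.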